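Working notes: a tosyloxy analogue of compound 1

This account rests on a few compounds, and the source may have more. Where it says the series, first, only, none or still open, it means among the compounds named here.

Measured so far:
compound 1 `Nc1cccc(Nc2c(C(=O)NCc3ccc(F)cc3)nc(Br)c3cccnc23)c1` — a functional assay on HCT-116 cells (Homo sapiens) for cytotoxicity, read by MTT assay, with a stated time of 72 h; on this read-out lower numbers stand for stronger inhibition and higher numbers for weaker inhibition: > 10000 nM (a limit of the assay, not a number)
compound 2 `N[C@H]1CC[C@H](Nc2c(C(=O)NCc3ccc(F)cc3)nc(N3CCCCC3)c3cccnc23)CC1` — this assay: 8000 nM
compound 3 `CN(C)c1ccc(CNC(=O)c2nc(Br)c3cccnc3c2N[C@H]2CC[C@H](N)CC2)cc1` — this assay: "not determined" (no result reported)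

Compound 1 stands only at the limit of > 10000 nM in this assay, at which 1 of the 3 values shown sits; the one further entry, compound 3, carries no number. Compound 4 `Cc1ccc(S(=O)(=O)Oc2c(C(=O)NCc3ccc(F)cc3)nc(Br)c3cccnc23)cc1` differs from compound 1 by ((4-methylphenyl)sulfonyl)oxy in place of (3-aminophenyl)amino on an aromatic carbon. Within the data shown here, no pair of measured compounds isolates this change, so nothing measured sizes the step. With compound 1 sitting at a limit, the step from compound 1 to compound 4 is expected to be none beyond the scatter, a step that the limit leaves unreadable from compound 1 to compound 4, with the real chance that only a limit is reported again. Compound 4 is estimated at 20000 nM, in the range 8000 nM to 50000 nM, in this assay.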

Compound 4, half-maximal inhibitory concentration: > 20000 nM
Compound 4 was reported as a limit; the forecaster's own chance of this, stated with the estimate: 70%; the middle value sits exactly at the limit.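

No step can be read between compound 1 and compound 4, since both stand only as limits of the assay. The compounds shown leave open whether ((4-methylphenyl)sulfonyl)oxy in place of (3-aminophenyl)amino changes anything in this assay.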